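The compounds below may be only part of what the source reports. "The series", "measured", "known", "first", "only" and "open" are said of these compounds alone.

Measured so far in a functional assay on NCI-H460 cells (Homo sapiens) for cytotoxicity, read by MTT assay, with a stated time of 48 h; on this read-out lower numbers stand for stronger inhibition and higher numbers for weaker inhibition:
- compound 1 `Cc1ccc2[nH]c(=O)c(-c3nc4cc([N+](=O)[O-])ccc4[nH]3)cc2c1` — a limit, > 100000 nM
- compound 2 `O=c1[nH]c2ccccc2cc1-c1nc2cc(F)ccc2[nH]1` — 24200 nM
- compound 3 `O=c1[nH]c2ccccc2cc1-c1nc2cc(Br)ccc2[nH]1` — 16800 nM

Compound 3 gives the lowest of the two numbers in this assay; its nearest neighbour is compound 2, and the step of a 1.4-fold lower number from compound 2 to compound 3 (0.16 log units; within the scatter) is within the scatter, so the two cannot be ordered. The value of compound 1 is a limit of the assay and not a number (the limit of > 100000 nM in this assay, at which 1 of the 3 values shown sits).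

Compound 4 `O=c1[nH]c2ccccc2cc1-c1nc2cc([N+](=O)[O-])ccc2[nH]1` is the next compound, and it differs from compound 3 in one place: nitro in place of bromo on an aromatic carbon. Within the data shown here, no measured step exchanges a halogen for a nitro group on the shared core, so the only direct bearing comes from the pair of values for compound 1 and compound 3. Compound 1 carries the same nitro group together with a methyl group on its core and reaches only the limit, whereas compound 3 gives a number. On that basis, the step of a 3.6-fold higher number from compound 3 to compound 4 (0.55 log units; beyond the scatter) is expected to run toward a higher number, well beyond the scatter. Compound 4 is therefore estimated at 60000 nM, with a range from 15000 nM to 200000 nM, and a real chance that this assay reports only a limit for it.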

Compound 4, half-maximal inhibitory concentration: > 100000 nM
Compound 4 was reported as a limit; the forecaster's own chance of this, stated with the estimate: 40%; at least 1.6-fold (0.22 log units) between middle value and limit.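

In this assay compound 4 gives > 100000 nM, which is a limit of the assay and not a number, so on the shared core without a methyl group the nitro group also ends at this limit: the limit of > 100000 nM in this assay, at which 2 of the 4 values shown sit.

At this aromatic carbon the kind of group therefore matters: nitro in place of bromo gives an at least 5.9-fold higher number from compound 3 to compound 4 (0.77 log units; beyond the scatter), and nitro in place of fluoro gives an at least 4.1-fold higher number from compound 2 to compound 4 (0.61 log units; beyond the scatter), both beyond the scatter, whereas the exchange between the two halogens, a 1.4-fold lower number from compound 2 to compound 3 (0.16 log units; within the scatter), stays within it. From the compounds shown here alone, the step that removes the methyl group cannot be read, as both of its values are limits, so the part played by that methyl group remains unknown.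

The compounds shown leave open whether the move to weaker inhibition belongs to the nitro group alone or would also appear with a nitrile, an amine or a carboxylic acid at this aromatic carbon. They also leave open how a methyl group on the core would act in a compound carrying bromo or fluoro, where the assay gives a number rather than a limit.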